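Opening a Ring into a Dimethoxymethyl Group

The source may hold more compounds than are shown below. What is called first, only, known or untested is meant among the compounds shown, and "the series" means these compounds.

Of the compounds shown here, three sharing one core have been measured in an assay on microsomes from liver for inhibition of sterol O-acyltransferase 1 (Rattus norvegicus); a lower number here means a stronger inhibitor, a higher number a weaker inhibitor. Compound 1 `COc1cccc(-c2nc(SCC3C[C@](C)(O)CC(=O)O3)[nH]c2-c2cccc(OC)c2)c1` gives 570 nM in this assay. Compound 2 `O=C1CCCC(CSc2nc(-c3ccccc3)c(-c3ccccc3)[nH]2)O1` gives 740 nM, and compound 3 `Clc1cccc(-c2[nH]c(SCC3CCCCO3)nc2-c2ccccc2)c1` gives 560 nM. Among these three numbers compound 2 has the highest, yet its gap to compound 1 and to compound 3 each stays within the usual scatter of this kind of measurement, so no order among the three can be read from the data.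

The next compound, compound 4 `COC(CSc1nc(-c2ccccc2)c(-c2ccccc2)[nH]1)OC`, has not yet been measured. It differs from compound 2 in one place: a group of 5 heavy atoms (3 carbon, 2 oxygen; no ring) in place of a group of 7 heavy atoms (5 carbon, 2 oxygen; one six-membered non-aromatic ring with 1 hetero atom), on a saturated chain carbon bound to a sulfur. In words, a group of 5 heavy atoms (3 carbon, 2 oxygen; no ring) replaces a group of 7 heavy atoms (5 carbon, 2 oxygen; one six-membered non-aromatic ring with 1 hetero atom), on a saturated chain carbon bound to a sulfur.

For the measured compounds named here, no measured pair in this set tracks such a change, so the expectation rests on the three numbers alone. The step from compound 2 to compound 4 is expected to be small in this assay, a 1.4-fold higher number from compound 2 to compound 4 (0.13 log units; within the scatter), leaning toward a somewhat higher number. Compound 4 is estimated at 1000 nM, with a range from 400 nM to 2500 nM.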

Compound 4, half-maximal inhibitory concentration: 580 nM
Beside the measured number, compound 4's estimate is 1.7-fold (0.24 log units) above it; measured number inside the range.
By their numbers in this assay, from the lowest: compounds 3, 1, 4 and 2 (each within the scatter of the next).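

On a saturated chain carbon bound to a sulfur, replacing one six-membered non-aromatic ring with an open dimethoxymethyl group gives a 1.3-fold lower number from compound 2 to compound 4 (0.11 log units; within the scatter) in this assay and so leaves the reading in the same range. For the compounds shown here, the earlier compounds offered no pair that differed in one place, so this is the first direct test of a change at this position, and in this pair the ring is not needed for a number of this size: a group with no ring and 5 heavy atoms reads like the ring with 7, and both groups have 2 hydrogen-bond acceptors and 0 donors. No separate measurement is available that could explain this result.

As far as these compounds go, it remains open how far this position accepts other kinds of group, such as an amine, a carboxylic acid or a longer carbon chain on the same carbon, since both groups compared here contain oxygen and carry no net charge. From the compounds shown here alone, it is also open whether the same swap would read alike on the core of compound 1 or compound 3.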